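A methyl for a fluoro on compound 3

The source may report more compounds than this note shows. Statements on the series, on what has been measured and on what is new or still open speak of the compounds shown alone.

Compound 3 `CCOc1ccc(-c2cc(NC(=O)c3ccc(F)cc3O)c[nH]c2=O)cc1` gives 51500 nM in an ADME assay on HepG2 2.2.15 cells (Homo sapiens) for cytotoxicity, read by CCK-8 assay, with a stated time of 8 days (a lower number here means that less compound is tolerated, a higher number that more compound is tolerated), and lies within the scatter of the two other measured compounds. Compound 2 `CCOc1ccc(-c2cc(NC(=O)c3cc(OC)ccc3O)c[nH]c2=O)cc1` stands at 57700 nM and compound 1 `Cc1cccc(-c2cc(NC(=O)c3ccc(C)cc3O)c[nH]c2=O)c1` at 75000 nM in this assay with no gap beyond the scatter among the three.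

Compound 4 `CCOc1ccc(-c2cc(NC(=O)c3ccc(C)cc3O)c[nH]c2=O)cc1` differs from compound 3 by a single change methyl in place of fluoro on an aromatic carbon with methyl in place of fluoro on an aromatic carbon. Among the measured compounds shown here, one measured step touches the same part of the structure: a 1.1-fold lower number from compound 2 to compound 3 (0.05 log units; within the scatter) and it stays within the scatter. Compound 1 already bears 2-hydroxy-4-methylphenyl on a different remainder and gives 75000 nM within the scatter of compound 3.

No step beyond the scatter is therefore expected, and the estimated move is a 1.1-fold higher number from compound 3 to compound 4 (0.05 log units; within the scatter) in this assay as a small one. In this assay the estimate for compound 4 is 58000 nM with an expected range from 35000 nM to 95000 nM around it.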

Compound 4, half-maximal cytotoxic concentration: > 100000 nM
Compound 4: a limit, no number (the forecaster's own chance of this, stated with the estimate: 10%); middle value at least 1.7-fold (0.23 log units) away from the limit.
By their numbers in this assay, from the lowest: compounds 3, 2 and 1 (each within the scatter of the next). At a limit, above all of these: compound 4.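

In this assay compound 4 gives > 100000 nM, which is a limit of the assay and not a number, and it is the only such limit among the compounds shown: the limit of > 100000 nM in this assay, at which 1 of the 4 values shown sits. At this aromatic carbon, meta to the hydroxy group, methyl in place of fluoro gives an at least 1.9-fold higher number from compound 3 to compound 4 (0.28 log units; that floor lies within the scatter), and the swap from 2-hydroxy-5-methoxyphenyl to 2-hydroxy-4-methylphenyl gives an at least 1.7-fold higher number from compound 2 to compound 4 (0.23 log units; that floor lies within the scatter). Changing the other end, 4-ethoxyphenyl in place of 3-methylphenyl gives an at least 1.3-fold higher number from compound 1 to compound 4 (0.12 log units; that floor lies within the scatter), so none of these steps is shown to lie beyond the scatter, though each is only a floor.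

The compounds shown leave open how far compound 4 lies past its limit. They also leave open how an amine, a carboxylic acid or an ethyl group on this aromatic carbon would read in this assay.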